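The compounds below may be only part of what the source reports. "The series", "measured", "known", "first", "only" and "open" are said of these compounds alone.

Measured in a functional assay on Jurkat cells (Homo sapiens) for antiproliferative activity, read by MTT assay, with a stated time of 72 h; on this read-out lower numbers stand for stronger inhibition and higher numbers for weaker inhibition:
Compound 1 `COc1cc(C(=O)c2sc3ccccc3c2-c2ccc(F)cc2)cc(OC)c1OC`: 2300 nM
Compound 2 `COc1cc(C(=O)c2sc3ccccc3c2-c2ccc(C)cc2)cc(OC)c1OC`: 3300 nM
Compound 3 `CCOc1ccc(-c2c(C(=O)c3cc(OC)c(OC)c(OC)c3)sc3ccccc23)cc1`: 4100 nM

These three compounds share a core and differ in one small group. Each step among them stays within the scatter: a 1.4-fold higher number from compound 1 to compound 2 (0.16 log units; within the scatter), a 1.8-fold higher number from compound 1 to compound 3 (0.25 log units; within the scatter) and a 1.2-fold higher number from compound 2 to compound 3 (0.09 log units; within the scatter). Compound 3, at 4100 nM, therefore cannot be told apart from compound 1 or compound 2.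

Compound 4 `COc1ccc(Nc2c(C(=O)c3cc(OC)c(OC)c(OC)c3)sc3ccccc23)cc1` has not been measured yet. Its difference is (4-methoxyphenyl)amino in place of 4-ethoxyphenyl on an aromatic carbon. In words, (4-methoxyphenyl)amino stands in place of 4-ethoxyphenyl on an aromatic carbon.

Going by the values given here, the measured steps bear on this only weakly, since they exchange fluoro, methyl and ethoxy, and none of the measured compounds carries the amino link. Their small size says little about a change of this kind, and the data give no direction for it. The expected result is a 1.4-fold lower number from compound 3 to compound 4 (0.14 log units; within the scatter), with no confident shift beyond the scatter. In this assay, the estimated value for compound 4 is 3000 nM, with an expected range from 500 nM to 12000 nM.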

Compound 4, half-maximal inhibitory concentration: 3500 nM
Beside the measured number, compound 4's estimate is 1.2-fold (0.07 log units) below it, within the range that was stated.
By their numbers in this assay, from the lowest: compounds 1, 2, 4 and 3 (each within the scatter of the next).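

In this assay, the place on the five-membered aromatic ring with 1 sulfur accepts a change of a new kind, since (4-methoxyphenyl)amino brings a nitrogen link and the amide-like hydrogen-bond donor counted above is replaced in plain terms by an amino hydrogen, and the result is a 1.2-fold lower number from compound 3 to compound 4 (0.07 log units; within the scatter). The comparisons with the other two groups agree, with a 1.1-fold higher number from compound 2 to compound 4 (0.03 log units; within the scatter) and a 1.5-fold higher number from compound 1 to compound 4 (0.18 log units; within the scatter), so this larger exchange stays as indistinguishable as the small ones on the outer ring. Nothing measured here explains this outcome.

Compound 4 differs from compound 3 in both the amino link and methoxy in place of ethoxy, so the two changes cannot be separated. The compounds shown also leave open how a longer chain as the link, or a carboxylic acid on the outer ring, would behave at this place.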